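The source may report more compounds than this note shows. Statements on the series, on what has been measured and on what is new or still open speak of the compounds shown alone.

Measured compounds:
compound 1 `COc1cc2c(=O)cc(-c3ccc(O)cc3)oc2c(OC)c1OC`: 0.7 ug/mL
compound 2 `COc1ccc(-c2cc(=O)c3c(OC)c(OC)c(OC)c(OC)c3o2)c(OC)c1`: 15 ug/mL
compound 3 `O=c1cc(-c2cccc([N+](=O)[O-])c2)oc2ccccc12`: 2 ug/mL

All three were tested in a functional assay on KB cells (Homo sapiens) for cytotoxicity; a higher number here means that more compound is needed for the effect, a lower number that less compound is needed. Among these numbers compound 3 stands second highest: compound 1 sits lower by a gap beyond the scatter, and compound 2 sits higher by a larger gap, also beyond the scatter. Compound 4 `CS(=O)(=O)Oc1cccc(-c2cc(=O)c3ccccc3o2)c1` differs from compound 3 in one place: (methylsulfonyl)oxy in place of nitro on an aromatic carbon. Going by the values given here, no measured pair shows this exchange, so its effect cannot be read from the data. The shared core is kept and the change is confined to one aromatic carbon, so only a small step is expected. Compound 4 is estimated to lie close to compound 3, with a step of a 1.5-fold higher number from compound 3 to compound 4 (0.18 log units; within the scatter) that may not exceed the scatter. In this assay compound 4 is estimated at 3 ug/mL, between 1 ug/mL and 10 ug/mL.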

Compound 4, concentration for half-maximal effect: > 100 ug/mL
Compound 4 gave a limit, no number; the forecaster's own chance of this, stated with the estimate: 5%; middle value at least 33-fold (1.52 log units) from the limit.
By their numbers in this assay, from the lowest: compound 1; then compound 3; then compound 2. At a limit, above all of these: compound 4.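

On this aromatic carbon, meta to a large group, putting (methylsulfonyl)oxy in place of nitro proves to be no small change in this assay, with an at least 50-fold higher number from compound 3 to compound 4 (1.69 log units; beyond the scatter). For compound 4 the result is a limit of the assay, not a number: > 100 ug/mL. This is the first step at this position among the compounds shown, and compound 4 alone stands at that limit: the limit of > 100 ug/mL in this assay, at which 1 of the 4 values shown sits.

As far as these compounds go, what an amine or a carboxylic acid on this same carbon would give remains open. From the compounds shown here alone, it is also open whether the same exchange on the core of compound 1 would give a step of this size.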